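A few compounds are considered here, and "the series" means these few. Any claim that something is new, unique, unknown or untested is made for them only; others in the source may bear on it.

- Compound 1 `CNC(=O)c1cc(Oc2ccc(C(=O)/C=C/c3ccc(F)cc3Cl)cc2)ccn1`: 4760 nM
- Compound 2 `CNC(=O)c1cc(Oc2ccc(C(=O)/C=C/c3cc(OC)c(OC)c(OC)c3)cc2)ccn1`: 3150 nM

In a functional assay on PC-3 cells (Homo sapiens) for cytotoxicity, read by MTT assay, with a stated time of 72 h (a lower number here means a stronger inhibitor, a higher number a weaker inhibitor), compound 1 gives 4760 nM and compound 2 gives 3150 nM. These two numbers lie within the usual scatter of each other, so the data do not separate the two compounds.

Compound 3 `CNC(=O)c1cc(Oc2ccc(C(=O)/C=C/c3ccc(Cl)cc3Cl)cc2)ccn1` keeps the core of compound 1 and alters one group: chloro in place of fluoro on an aromatic carbon. This puts chloro in place of fluoro on an aromatic carbon, turning 2-chloro-4-fluorophenyl into 2,4-dichlorophenyl. Among the compounds with values here, no pair of measured compounds shows this swap, so the data offer no direct guide to its size. With a single small group exchanged, no shift beyond the scatter is expected in this assay. The expected step is a 1.2-fold lower number from compound 1 to compound 3 (0.08 log units; within the scatter). For compound 3 the estimated value is 4000 nM, with an expected range of 1600 nM to 10000 nM.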

Compound 3, half-maximal inhibitory concentration: 9220 nM
Compound 3: middle estimate off by 2.3-fold (0.36 log units), on the low side; the range from low to high includes it.
By their numbers in this assay, from the lowest: compounds 2, 1 and 3 (each within the scatter of the next, the first and the last beyond it).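

In this assay, within the data shown here, the exchange of fluoro for chloro, on the aromatic carbon para to a large group and meta to a chloro group, gives a 1.9-fold higher number from compound 1 to compound 3 (0.29 log units; within the scatter) and provides the first step between two compounds that differ in one place. At this position, then, going from 2-chloro-4-fluorophenyl to 2,4-dichlorophenyl does not separate the two compounds in this assay, so one halogen exchange here leaves no effect that can be told from ordinary repeat variation. No measurement shown offers a reason for the size of this step.

Still open, as far as these compounds go, is whether a group of a different kind at this position, such as an amine or a carboxylic acid, would move the number beyond the scatter. The compounds shown also leave open how a hydrogen there would compare with fluoro or chloro.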